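This account rests on a few compounds, and the source may have more. Where it says the series, first, only, none or still open, it means among the compounds named here.

Compound 1 `COc1ccc(/C=N\NC(=S)NC(C)(C)CCC[C@](C)(O)[C@@H]2CC=C(C)CC2)cc1` was measured in a functional assay on PCO3 cells (Homo sapiens) for cytotoxicity, read by sulforhodamine B assay (on this read-out lower numbers stand for stronger inhibition of growth and higher numbers for weaker inhibition of growth), where compound 1 gives 7660 nM. Among the three compounds measured so far its number is the second highest: compound 2 `CC1=CC[C@@H]([C@@](C)(O)CCCC(C)(C)NC(=S)N/N=C\c2cccc([N+](=O)[O-])c2)CC1` gives 5600 nM, and the step of a 1.4-fold lower number from compound 1 to compound 2 (0.14 log units; within the scatter) stays within the scatter, whereas compound 3 `CC1=CC[C@@H]([C@@](C)(O)CCCC(C)(C)NC(=S)N/N=C\c2ccc([N+](=O)[O-])cc2)CC1` gives 18100 nM, and the step of a 2.4-fold higher number from compound 1 to compound 3 (0.37 log units; beyond the scatter) lies beyond it. The remaining measured step, a 3.2-fold higher number from compound 2 to compound 3 (0.51 log units; beyond the scatter), also lies beyond the scatter.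

Compound 4 `CC1=CC[C@@H]([C@@](C)(O)CCCC(C)(C)NC(=S)N/N=C(/C)c2ccccc2)CC1` differs from compound 1 in one place: a group of 9 heavy atoms (8 carbon, 1 nitrogen; one six-membered aromatic ring of carbon only) in place of a group of 10 heavy atoms (8 carbon, 1 nitrogen, 1 oxygen; one six-membered aromatic ring of carbon only), on an amide-type nitrogen, the nitrogen whose other neighbour is the thiocarbonyl carbon. Among the compounds with values here, none of the measured steps makes this exact change. The two steps that start from compound 1 only exchange the substituent on the aromatic ring, and they moved the number by a 1.4-fold lower number from compound 1 to compound 2 (0.14 log units; within the scatter) and a 2.4-fold higher number from compound 1 to compound 3 (0.37 log units; beyond the scatter), that is, within the scatter or modestly beyond it. Within the data shown here, with no closer precedent, the change is expected to give no more than a small step in this assay, with no firm direction, and a slightly higher number is taken as the middle of the expectation. Compound 4 is therefore estimated at 9000 nM, between 3500 nM and 25000 nM, which would mean a step of a 1.2-fold higher number from compound 1 to compound 4 (0.07 log units; within the scatter).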

Compound 4, concentration for 50% growth inhibition: 20000 nM
For compound 4 the middle estimate is 2.2-fold (0.35 log units) below the measured one, within the range that was stated.
By their numbers in this assay, from the lowest: compounds 2 and 1 (each within the scatter of the next); then compounds 3 and 4 (each within the scatter of the next).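

In this assay, replacing the whole group on the amide-type nitrogen gives a 2.6-fold higher number from compound 1 to compound 4 (0.42 log units; beyond the scatter), a modest step beyond the scatter, which shows that the number at this place can move when the oxygen-bearing group of compound 1 gives way to a group without oxygen, one that has a single hydrogen-bond acceptor rather than two. Compound 4 is the only compound shown whose group at this place holds no oxygen, whereas the earlier steps compared groups that all contain oxygen, and only two of those three steps went beyond the scatter. Nothing available explains why the number moved in this direction.

Within the data shown here, the single step does not separate the loss of the oxygen-bearing substituent from the other differences between the two groups, so it remains unclear which part of the change accounts for the higher number. As far as these compounds go, it also remains open how this assay would respond to an amine or a carboxylic acid on the aromatic ring of this group, or to a longer chain in place of the group on the amide-type nitrogen.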